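This account rests on a few compounds, and the source may have more. Where it says the series, first, only, none or still open, it means among the compounds named here.

Measured in a functional assay on MCF7 cells (Homo sapiens) for inhibition, read by sulforhodamine B assay; a higher number here means a weaker inhibitor, a lower number a stronger inhibitor:
- compound 1 `COc1ccccc1NC1=CC(=O)c2c(nc3n2[C@H]2OC[C@@H](O)[C@H]2OC3)C1=O`: 6580 nM
- compound 2 `O=C1C(NC2CC2)=CC(=O)c2c1nc1n2[C@H]2OC[C@@H](O)[C@H]2OC1`: > 16000 nM

The entry for compound 2 is a limit and not a number. Compound 2 stands at the limit of > 16000 nM in this assay, at which 1 of the 2 values shown sits.

Compound 3 `COc1cccc(NC2=CC(=O)c3c(nc4n3[C@H]3OC[C@@H](O)[C@H]3OC4)C2=O)c1` differs from compound 2 by 3-methoxyphenyl in place of cyclopropyl on an amine nitrogen.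

Going by the values given here, the only measured step bearing on this is an at least 2.4-fold higher number from compound 1 to compound 2 (0.38 log units; beyond the scatter), which lies beyond the scatter. It is the same kind of swap on the same nitrogen, run the other way. Compound 1 carries 2-methoxyphenyl and compound 3 carries 3-methoxyphenyl, and no measurement compares the two, so the return to the value of compound 1 is uncertain.

Expected in this assay is an at least 2.6-fold lower number from compound 2 to compound 3 (0.42 log units; beyond the scatter), a move toward stronger inhibition. Compound 3 is estimated at 6000 nM, with an expected range of 2000 nM to 16000 nM.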

Compound 3, half-maximal inhibitory concentration: 3830 nM
For compound 3 the middle estimate is 1.6-fold (0.19 log units) above the measured one; the measured number falls inside the stated range.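

In this assay, the gain from an aromatic group on this amine nitrogen does not depend on the 2-methoxyphenyl of compound 1 alone, as 3-methoxyphenyl also stands clear of cyclopropyl: an at least 4.1-fold lower number from compound 2 to compound 3 (0.62 log units; beyond the scatter). Moving the methoxy group from one methoxyphenyl to the other does not separate the two compounds: a 1.7-fold lower number from compound 1 to compound 3 (0.24 log units; within the scatter). The entry for compound 2 is a limit and not a number, which leaves the full size of the cyclopropyl step unknown: the limit of > 16000 nM in this assay, at which 1 of the 3 values shown sits.

Going by these compounds, whether the aromatic ring alone carries the difference, or the methoxy group contributes to it, stays open, and plain phenyl would bear on that. Also open, on these data alone, is whether benzyl, with a carbon set between the ring and the amine nitrogen, keeps the value of compound 3.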